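Swapping the aminophenyl arm for a chloropyridine

The compounds below may be only part of what the source reports. "The series", "measured", "known", "first", "only" and "open" are said of these compounds alone.

Measured compounds:
compound 1 `Cc1ncc([N+](=O)[O-])n1CCSc1nnc(-c2ccc(N)cc2)o1` — 6700 nM
compound 2 `Cc1ncc([N+](=O)[O-])n1CCSc1nnc(-c2ccc(N(C)C)cc2)o1` — 11900 nM
compound 3 `COc1cc(OC)cc(-c2nnc(SCCn3c([N+](=O)[O-])cnc3C)o2)c1` — 10500 nM

Of the compounds shown here, three sharing one core have been tested in a functional assay on HepG2 cells (Homo sapiens) for cytotoxicity, read by MTT assay, with a stated time of 48 h; on this read-out higher numbers stand for weaker inhibition and lower numbers for stronger inhibition. Compound 1 gives the lowest of the three numbers, but its neighbours sit close: compound 3 differs by a gap that is within the scatter, and the step of a 1.8-fold higher number from compound 1 to compound 2 (0.25 log units; within the scatter) is likewise within the scatter. The three numbers therefore cannot be ranked against each other in this assay.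

Compound 4 `Cc1ncc([N+](=O)[O-])n1CCSc1nnc(-c2ccnc(Cl)c2)o1` is not yet measured. It differs from compound 1 in one place: 2-chloropyridin-4-yl in place of 4-aminophenyl on an aromatic carbon. Among the compounds with values here, of the measured steps, only the one from compound 1 to compound 2 bears on this position, since it also alters the group on the six-membered aromatic ring attached to the five-membered aromatic ring with 2 nitrogen and 1 oxygen; that step, a 1.8-fold higher number from compound 1 to compound 2 (0.25 log units; within the scatter), did not leave the scatter. Compound 3, carrying a different pattern on the same ring, also stays within the scatter of compound 1. Within the data shown here, nothing measured so far touches a ring with a hetero atom or a chlorine at this place, so the expectation rests on the absence of movement in the steps at hand. Compound 4 is therefore expected at 8000 nM in this assay, with a range from 3000 nM to 25000 nM, which means an expected step of a 1.2-fold higher number from compound 1 to compound 4 (0.08 log units; within the scatter) that stays within the scatter.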

Compound 4, half-maximal inhibitory concentration: 11600 nM
For compound 4 the middle estimate is 1.5-fold (0.16 log units) below the measured one, and the stated range covers the measured number.
By their numbers in this assay, from the lowest: compounds 1, 3, 4 and 2 (each within the scatter of the next).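

Replacing 4-aminophenyl with 2-chloropyridin-4-yl on the aromatic carbon of the five-membered ring gives a 1.7-fold higher number from compound 1 to compound 4 (0.24 log units; within the scatter) in this assay. The earlier compounds shown here had varied only the groups on a six-membered aromatic ring of carbon only, whereas compound 4 brings a ring hetero atom and a chlorine to this place and has no hydrogen-bond donor, yet its number still cannot be separated from that of compound 1. This position therefore tolerates a change of the ring itself in this cytotoxicity read-out, at least for this one pair, although no accompanying data offer any explanation for that result.

The ring nitrogen and the chlorine enter together, so the compounds shown cannot tell their contributions apart, and a plain pyridin-4-yl or a 4-chlorophenyl group would be needed to separate them. From the compounds shown here alone, it also stays open whether any replacement at this place can move the number beyond the scatter, for example a carboxylic acid on the ring or a piperidine in place of the aromatic ring.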